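Series notes: halogen swap on the benzyl ring

The source may report more compounds than this note shows. Statements on the series, on what has been measured and on what is new or still open speak of the compounds shown alone.

Compound 3 `Oc1ccc(CC(O)CN2CCC(O)(Cc3ccc(Br)cc3)CC2)cc1` stands at the top of the numbers in hand: in an assay on isolated protein for binding affinity to Adrenergic receptor alpha-1 (Homo sapiens), read by radioligand binding (a higher number here means a weaker inhibitor, a lower number a stronger inhibitor), compound 3 gives 2440 nM. The other members of the set sit well beneath it. Compound 1 `CC(Cc1ccc(O)cc1)CN1CCC(Cc2ccccc2)CC1` gives 91.5 nM in this assay, and compound 2 `Oc1ccc(C(O)CCN2CCC(Cc3ccccc3)CC2)cc1` gives 24.4 nM. Within the data shown here, no one-point step between these three is known, so compound 3 can be placed only by its own value.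

Compound 4 `Oc1ccc(CC(O)CN2CCC(O)(Cc3ccc(Cl)cc3)CC2)cc1` follows from compound 3 through (chloro in place of bromo on an aromatic carbon), chloro in place of bromo on an aromatic carbon. For a change of this kind in this assay no step beyond the scatter is expected, in either direction, and the estimated step is a 1.1-fold higher number from compound 3 to compound 4 (0.06 log units; within the scatter). Compound 4 is therefore expected at 2800 nM, within the range 1200 nM to 6500 nM.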

Compound 4, inhibition constant: 5610 nM
Estimate against measurement, compound 4: 2.0-fold (0.30 log units) below; the range from low to high includes it.
By their numbers in this assay, from the lowest: compound 2; then compound 1; then compound 3; then compound 4.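

In this assay, among these compounds, the halogen on this aromatic carbon is not a silent swap: 4-bromobenzyl to 4-chlorobenzyl gives a 2.3-fold higher number from compound 3 to compound 4 (0.36 log units; beyond the scatter) and is the first one-place comparison in the set, with the bromo compound holding the lower number. The step is modest, and it rests on a single pair. Nothing in hand explains its direction.

Going by these compounds, with only bromo and chloro at this position, any trend remains open. Fluoro, methyl or methoxy on the same aromatic carbon would show whether the number keeps rising or turns back.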